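The compounds below may be only part of what the source reports. "The series", "measured", "known", "first", "only" and "open" are said of these compounds alone.

Of the compounds shown here, two built on the same core have been measured in an in vitro assay on BTI-TN-5B1-4 cells for inhibition of Amine oxidase [flavin-containing] A (Homo sapiens), read by Amplex Red, with a stated time of 15 min, tested at 100 uM; on this read-out higher numbers stand for more inhibition at the one concentration tested (going by the name of the read-out) and lower numbers for less inhibition. Compound 1 `C/C(=N/Nc1nc(-c2ccc(F)cc2)cs1)c1cccs1` gives 40% in this assay. Compound 2 `C/C(=N/Nc1nc(-c2ccc(F)cc2F)cs1)c1cccs1` gives 40% in this assay. The only measured step, no change at the digits printed from compound 1 to compound 2 (within the scatter), puts fluoro in place of hydrogen on an aromatic carbon and leaves the read-out where it was, within the scatter, so on the numbers shown compound 2 stands level with compound 1.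

Compound 3 `C/C(=N/Nc1nc(-c2ccc(F)cc2F)cs1)c1ccncc1` has not yet been measured. It differs from compound 2 in a single place: pyridin-4-yl in place of thiophen-2-yl on a carbon with a double bond to nitrogen. Within the data shown here, no measured step exchanges one ring for another on the carbon with a double bond to nitrogen; the fluoro step concerns a different part of the molecule and offers no guidance on the size or direction of this change. The expectation therefore rests on compound 2 alone and carries a wide range. Compound 3 is expected to give about 30% in this assay, most likely between 8% and 55%. The expected step from compound 2 to compound 3 is a number 10 percentage points lower from compound 2 to compound 3 (within the scatter), a modest fall that may itself lie within the scatter.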

Compound 3, a percentage reported as inhibition, at one concentration (the size of the read-out at that concentration, not a potency): 40%
Compound 3: the middle estimate sits 10 percentage points below what was measured; the measured number falls inside the stated range.
By their numbers in this assay, from the lowest: compounds 1, 2 and 3 (each within the scatter of the next).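

In this assay, among these compounds, the exchange of thiophen-2-yl for pyridin-4-yl on the carbon with a double bond to nitrogen gives no change at the digits printed from compound 2 to compound 3 (within the scatter) and is the first measured change at this position, since the earlier step concerned a fluoro group elsewhere in the molecule. Here the ring grows from five to six members and its hetero atom changes from sulfur to nitrogen, yet the read-out stays within the scatter, so for this pair the position accepts either aromatic ring at the one concentration tested. Nothing available explains why the two rings give matching results.

One pair cannot show whether this holds for other groups at the same place, such as a plain phenyl ring, a saturated piperidine ring or a thiophene carrying a carboxylic acid. A percentage at a single concentration is also not a potency, so any difference in potency among these compounds remains open, as does the effect of replacing the methyl group on the same carbon with a longer chain.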